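The compounds below may be only part of what the source reports. "The series", "measured", "known", "first", "only" and "open" are said of these compounds alone.

The measured compounds:
Compound 1 `N#Cc1ccc(-n2cc(COc3cccc(NC(=O)Nc4ccc(Cl)c(C(F)(F)F)c4)c3)nn2)cc1` gives 2980 nM in a functional assay on HepG2 cells (Homo sapiens) for inhibition, read by MTT assay, with a stated time of 72 h; a higher number here means a weaker inhibitor, a lower number a stronger inhibitor.
Compound 2 `O=C(Nc1cccc(OCc2cn(-c3ccccc3Cl)nn2)c1)Nc1ccc(Cl)c(C(F)(F)F)c1` gives 1960 nM in this assay.
Compound 3 `O=C(Nc1cccc(OCc2cn(-c3ccccc3I)nn2)c1)Nc1ccc(Cl)c(C(F)(F)F)c1` gives 2870 nM in this assay.

Among these three numbers compound 1 has the highest, but the gaps to the others are small: a 1.5-fold lower number from compound 1 to compound 2 (0.18 log units; within the scatter) and a 1.0-fold lower number from compound 1 to compound 3 (0.02 log units; within the scatter), both within the scatter. Between the two halogen-bearing analogues, a 1.5-fold higher number from compound 2 to compound 3 (0.17 log units; within the scatter), again within the scatter.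

Compound 4 `O=C(Nc1cccc(OCc2cn(-c3cccc(I)c3)nn2)c1)Nc1ccc(Cl)c(C(F)(F)F)c1` has not yet been measured in this assay. It differs from compound 1 in one place: 3-iodophenyl in place of 4-cyanophenyl on an aromatic nitrogen. For the measured compounds named here, the steps that bear on this change exchange the same 4-cyanophenyl for 2-chlorophenyl or 2-iodophenyl, a 1.5-fold lower number from compound 1 to compound 2 (0.18 log units; within the scatter) and a 1.0-fold lower number from compound 1 to compound 3 (0.02 log units; within the scatter); neither leaves the scatter, and the exchange of iodo for chloro, a 1.5-fold higher number from compound 2 to compound 3 (0.17 log units; within the scatter), does not either. Going by the values given here, no measured step therefore points to a shift beyond the scatter when 3-iodophenyl is introduced. Compound 4 is expected to give about 2600 nM in this assay, with a range of 1200 nM to 5500 nM. This estimate means a step of a 1.1-fold lower number from compound 1 to compound 4 (0.06 log units; within the scatter), which is expected to stay within the scatter.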

Compound 4, half-maximal inhibitory concentration: 4780 nM
Estimate against measurement, compound 4: 1.8-fold (0.26 log units) below; the range from low to high includes it.
By their numbers in this assay, from the lowest: compounds 2, 3, 1 and 4 (each within the scatter of the next, the first and the last beyond it).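

In this assay, 3-iodophenyl in place of 4-cyanophenyl gives a 1.6-fold higher number from compound 1 to compound 4 (0.21 log units; within the scatter) and moving to it from 2-iodophenyl gives a 1.7-fold higher number from compound 3 to compound 4 (0.22 log units; within the scatter), so neither change is resolved at this position on the aromatic nitrogen. For the compounds shown here, the exchange of 2-chlorophenyl for 3-iodophenyl is the first step here to leave the scatter, with a 2.4-fold higher number from compound 2 to compound 4 (0.39 log units; beyond the scatter) marking compound 4 as a modestly weaker inhibitor than compound 2, although this step changes both the halogen and its place on the phenyl ring. No evidence is available to explain these steps.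

The compounds shown leave open whether the halogen or its place accounts for that step, which 3-chlorophenyl could separate. They also leave open whether an amine or a carboxylic acid on this phenyl ring would shift the number beyond the scatter from compound 1.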